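The compounds below may be only part of what the source reports. "The series", "measured", "known", "first", "only" and "open" are said of these compounds alone.

Measured in a functional assay on SGC-7901 cells (Homo sapiens) for antiproliferative activity, read by MTT assay, with a stated time of 72 h; a higher number here means a weaker inhibitor, a lower number a stronger inhibitor:
- Compound 1 `COc1ccc(-c2ssc(=S)c2-c2cc(OC)c(OC)c(OC)c2)cc1`: 21100 nM
- Compound 2 `COc1ccc(-c2c(-c3cc(OC)c(OC)c(OC)c3)ssc2=S)cc1N`: 2620 nM
- Compound 3 `COc1ccc(-c2ss/c(=N/O)c2-c2cc(OC)c(OC)c(OC)c2)cc1`: 17400 nM

Going by the values given here, only three compounds have been measured so far, so there is little to compare. Compound 3, at 17400 nM, sits level with compound 1 within the usual scatter of repeat measurements. Its number is higher than that of compound 2, and that gap lies beyond the scatter, so compound 3 belongs to the weaker end of this small set.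

Compound 4 `COc1ccc(-c2ss/c(=N/O)c2-c2cc(OC)c(OC)c(OC)c2)cc1O` is compound 3 with one change: hydroxy in place of hydrogen on an aromatic carbon. Hydroxy takes the place of hydrogen on an aromatic carbon, turning 4-methoxyphenyl into 3-hydroxy-4-methoxyphenyl. Among the compounds with values here, no two measured compounds differ in this way, so the data give no direct precedent for the size of the effect. Within the data shown here, the only guide is that compound 2, at 2620 nM, shows that a clearly lower number is reachable within this set.

A moderate move towards a lower number in this assay is therefore expected, though a result within the scatter of compound 3 remains possible. The estimated step is a 2.9-fold lower number from compound 3 to compound 4 (0.46 log units; beyond the scatter). For compound 4 the estimated value is 6000 nM, with an expected range of 1500 nM to 20000 nM.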

Compound 4, half-maximal inhibitory concentration: 200 nM
The estimate for compound 4 lay 30-fold (1.48 log units) above the measured number, outside the stated range (below it).
By their numbers in this assay, from the lowest: compound 4; then compound 2; then compounds 3 and 1 (each within the scatter of the next).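

Turning 4-methoxyphenyl into 3-hydroxy-4-methoxyphenyl gives in this assay an 87-fold lower number from compound 3 to compound 4 (1.94 log units; beyond the scatter) and this is the only change in a single place that can be read so far. It shows that this aromatic carbon, ortho to a methoxy group and meta to a large group, is a highly sensitive spot on compound 3, where what it carries strongly shifts the number. The change itself is small, a hydrogen giving way to a hydroxy group of one heavy atom, yet the step it brings is large, and nothing among the available data explains how it arises.

As far as these compounds go, how a fluorine atom or a second methoxy group would fare on this same carbon remains open, and with it the question of whether hydroxy in particular is what counts. Also open, from the compounds shown here alone, is whether hydroxy would bring a similar step on the core of compound 1, as a single step on a single core cannot settle whether the effect carries over to another.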